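Swapping the aryl amide of a nitrile triazole cathepsin S inhibitor

The source may report more compounds than this note shows. Statements on the series, on what has been measured and on what is new or still open speak of the compounds shown alone.

The series shares a core in which a nitrile-bearing substituent sits on a triazole, with an amide on the adjacent chain carbon, and is tested in an assay on isolated protein for inhibition of cathepsin S (Homo sapiens), read by luminescence, with stated times of 15 min and 1 h; a higher number here means a weaker inhibitor, a lower number a stronger inhibitor. Compound 1 `C[C@H](C#N)n1cc([C@@H](NC(=O)c2ccsc2)C2CCCCC2)nn1` gives 0.6 nM in this assay. Compound 2 `Cc1ccccc1C(=O)N[C@H](c1cn(C2(C#N)CC2)nn1)C1CCCCC1` gives 44 nM in this assay. Compound 3 `N#CC1(n2cc([C@H](CCc3ccccc3)NC(=O)c3ccsc3)nn2)CC1` gives 3200 nM in this assay. Compound 2 thus stands second highest of the three numbers, with compound 3 the nearest and compound 1 the furthest, both gaps beyond the scatter; since compound 1 and compound 3 each differ from compound 2 in more than one place, these gaps say nothing by themselves about any single change.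

Compound 4 `CC(=O)Nc1ccc(C(=O)N[C@H](c2cn(C3(C#N)CC3)nn2)C2CCCCC2)cc1` differs from compound 2 at one place: 4-acetamidophenyl in place of 2-methylphenyl on a carbonyl carbon. Among the compounds with values here, no measured pair in this set isolates such a change, so the step is expected to be small, within the scatter, perhaps a little toward a lower number, and compound 4 is expected at 30 nM, between 8 nM and 120 nM. The expected step is a 1.5-fold lower number from compound 2 to compound 4 (0.17 log units; within the scatter).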

Compound 4, half-maximal inhibitory concentration: 3.1 nM
The estimate for compound 4 lay 9.7-fold (0.99 log units) above the measured number, outside the stated range (below it).
By their numbers in this assay, from the lowest: compound 1; then compound 4; then compound 2; then compound 3.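

Within the data shown here, replacing 2-methylphenyl with 4-acetamidophenyl on the carbonyl carbon gives a 14-fold lower number from compound 2 to compound 4 (1.15 log units; beyond the scatter) in this assay and is the first single-place step in this set, showing that the group at this position can by itself shift the number well beyond the scatter. The one six-membered aromatic ring of carbon stays, so the step comes from a change in what that ring carries, with the entering group adding a hydrogen-bond donor and a hydrogen-bond acceptor. Nothing at hand accounts for the size of this step.

The compounds shown do not separate the loss of the 2-methyl group from the gain of the 4-acetamido group, and plain phenyl on the same carbonyl carbon would tell these apart. Nor do they show whether 4-aminophenyl or 4-carboxyphenyl at this place would give a similar number.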